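Shortening the chain and dropping the sulfur in compound 4

This account rests on a few compounds, and the source may have more. Where it says the series, first, only, none or still open, it means among the compounds named here.

Compound 3, with the structure `CCCC[S+]([O-])c1nc(N)c2nc(O)n(Cc3ccccc3)c2n1`, is one of three close relatives tested in a functional assay on the whole organism for activation, with Mus musculus as the target; a higher number here means that more compound is needed for the effect, a lower number that less compound is needed. Compound 3 gives 1 mg/kg. Compound 2, `CCCCCSc1nc(N)c2nc(O)n(Cc3ccccc3)c2n1`, gives 1 mg/kg, and compound 1, `CCCCCOc1nc(N)c2nc(O)n(Cc3ccccc3)c2n1`, gives 0.3 mg/kg. Within this set compound 3 stands level with compound 2 and together with it has the highest number, with no change at the digits printed from compound 2 to compound 3 (within the scatter) and a 3.3-fold higher number from compound 1 to compound 3 (0.52 log units; beyond the scatter).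

Compound 4, `CCOc1nc(N)c2nc(O)n(Cc3ccccc3)c2n1`, has not yet been measured. Compared with compound 3, (a group of 3 heavy atoms (2 carbon, 1 oxygen; no ring) in place of a group of 6 heavy atoms (4 carbon, 1 oxygen, 1 sulfur; no ring), on an aromatic carbon). For the measured compounds named here, the change brings back an oxygen-linked chain as in compound 1, but shorter; no measured pair shows the effect of chain length alone. The closest guide is the step between compound 1 and compound 3, namely a 3.3-fold higher number from compound 1 to compound 3 (0.52 log units; beyond the scatter), which an oxygen-linked chain would be expected to undo. The estimate therefore is a 2.0-fold lower number from compound 3 to compound 4 (0.30 log units; within the scatter), with compound 4 expected to give 0.5 mg/kg, within 0.15 mg/kg to 3 mg/kg.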

Compound 4, minimum effective dose: 0.3 mg/kg
Estimate against measurement, compound 4: 1.7-fold (0.22 log units) above; measured number inside the range.
By their numbers in this assay, from the lowest: compounds 1 and 4 (each within the scatter of the next); then compounds 2 and 3 (each within the scatter of the next).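

In this assay, shortening the chain on the aromatic carbon between two ring nitrogen atoms from pentyloxy to ethoxy has no visible effect (in other words, no change at the digits printed from compound 1 to compound 4 (within the scatter)). Chain length alone therefore does not register across this oxygen-linked pair. The two sulfur-containing compounds both stand apart from the ethoxy compound (a 3.3-fold lower number from compound 2 to compound 4 (0.52 log units; beyond the scatter) and a 3.3-fold lower number from compound 3 to compound 4 (0.52 log units; beyond the scatter)), so among these four compounds, the two oxygen-linked chains share the lower number and the two sulfur-containing chains the higher, with none going against this split.

Going by these compounds, how a methoxy group, a chain longer than pentyloxy or an amine at this position would compare remains open. Nothing available here explains why the two kinds of chain differ.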